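A few compounds are considered here, and "the series" means these few. Any claim that something is new, unique, unknown or untested is made for them only; others in the source may bear on it.

Measured in a functional assay on U-937 cells (Homo sapiens) for antiproliferative activity, read by MTT assay, with a stated time of 24 h; a lower number here means a stronger inhibitor, a higher number a weaker inhibitor:
compound 1 `CCCCc1oc2ccccc2c1C(=O)c1ccc(OCC(=O)NC(C)C)cc1` gives 17500 nM
compound 2 `CCCCc1oc2ccccc2c1C(=O)c1ccc(OCC(=O)N2CCCCC2)cc1` gives 37100 nM
compound 3 `CCCCc1oc2ccccc2c1C(=O)c1ccc(OCC(=O)NCc2ccccc2)cc1` gives 16300 nM

Compound 3 stands level with compound 1 (a 1.1-fold lower number from compound 1 to compound 3 (0.03 log units; within the scatter)), while compound 2 lies apart from both (a 2.1-fold higher number from compound 1 to compound 2 (0.33 log units; beyond the scatter); a 2.3-fold lower number from compound 2 to compound 3 (0.36 log units; beyond the scatter)). Compound 4 `CCCCNC(=O)CCCOc1ccc(C(=O)c2c(CCCC)oc3ccccc23)cc1` follows from compound 3 by one change (2-(butylcarbamoyl)ethyl in place of benzylcarbamoyl on a saturated chain carbon bound to an oxygen on an aromatic ring), with 2-(butylcarbamoyl)ethyl in place of benzylcarbamoyl on a saturated chain carbon bound to an oxygen on an aromatic ring. Going by these compounds, the three measured steps bear only on the amide end, and none alters the saturated chain, so the direction stays open. At most a modest step is expected, and the estimated step is small (a 1.2-fold higher number from compound 3 to compound 4 (0.09 log units; within the scatter)). The estimate for compound 4 is 20000 nM (range 8000 nM to 50000 nM).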

Compound 4, half-maximal inhibitory concentration: 24600 nM
Beside the measured number, compound 4's estimate is 1.2-fold (0.09 log units) below it; measured number inside the range.
By their numbers in this assay, from the lowest: compounds 3, 1, 4 and 2 (each within the scatter of the next, the first and the last beyond it).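

In this assay, 2-(butylcarbamoyl)ethyl in place of benzylcarbamoyl on a saturated chain carbon bound to an oxygen on an aromatic ring stays within the scatter (a 1.5-fold higher number from compound 3 to compound 4 (0.18 log units; within the scatter)), and the steps from the other two amides do too (a 1.4-fold higher number from compound 1 to compound 4 (0.15 log units; within the scatter); a 1.5-fold lower number from compound 2 to compound 4 (0.18 log units; within the scatter)). This position therefore tolerates the (benzylcarbamoyl)methyl to 3-(butylcarbamoyl)propyl difference without a step beyond the scatter. No evidence on the cause of these steps is available.

The chain and the amide end change together here, and their separate contributions cannot be read. Going by these compounds, how a carboxylic acid or an amine at the chain end would compare remains open.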